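Cytotoxicity Limits in a Biaryl Amide Series

A few compounds are considered here, and "the series" means these few. Any claim that something is new, unique, unknown or untested is made for them only; others in the source may bear on it.

Compound 2 `CC(C)N(Cc1cccc(OCCCCCC(=O)O)c1)C(=O)c1ccc(-c2ccc3c(c2)OCCO3)cc1` was tested in an ADME assay on Raji cells (Homo sapiens) for cytotoxicity, read by CellTiter-Glo and resazurin assay, with a stated time of 72 h; a lower number here means that less compound is needed, a higher number that more compound is needed for the effect. In this assay compound 2 reaches only the limit of > 21900 nM. Its relative compound 1 `CC(C)N(Cc1cccc(OCCCCCC(=O)O)c1)C(=O)c1ccc(-c2cccc(N(C)C)c2)cc1` likewise gives only the limit of > 26000 nM in this assay. The step that the two limits leave unreadable from compound 1 to compound 2 cannot be sized because the limit of > 21900 nM in this assay, at which 1 of the 2 values shown sits, and the limit of > 26000 nM in this assay, at which 1 of the 2 values shown sits, are where both readings sit. Compound 3 `COc1cc(F)cc(-c2ccc(C(=O)N(Cc3cccc(OCCCCCC(=O)O)c3)C(C)C)cc2)c1` carries 3-fluoro-5-methoxyphenyl in place of 2,3-dihydro-1,4-benzodioxin-6-yl on an aromatic carbon. No readable measured step bears on this change, so the expected step is a step that the limit leaves unreadable from compound 2 to compound 3, with no shift beyond the scatter anticipated. Compound 3 is estimated at 25000 nM, within 8000 nM to 80000 nM, most probably reported again only as a limit.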

Compound 3, half-maximal effective concentration: > 26000 nM
Compound 3: only a limit was reported; the forecaster's own chance of this, stated with the estimate: 75%; middle value at least 1.0-fold (0.01 log units) from the limit.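

In this assay compound 3 gives only a limit, > 26000 nM. Going by these compounds alone, no step among compound 1, compound 2 and compound 3 can be read from limits alone. Open remains where each compound's true value lies, and whether exchanging the group changes it.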